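Enamine-linked bisphenol series: cyclohexylamino analogue of compound 2

A few compounds are considered here, and "the series" means these few. Any claim that something is new, unique, unknown or untested is made for them only; others in the source may bear on it.

Measured so far:
compound 1 `CCC(C)NC(=C\C(=O)/C=C/c1ccc(O)c(OC)c1)/C=C/c1ccc(O)c(OC)c1` gives 0.13%
compound 2 `CC(C)CNC(=C\C(=O)/C=C/c1ccc(O)cc1)/C=C/c1ccc(O)cc1` gives 0.02%
compound 3 `CCC(C)NC(=C\C(=O)/C=C/c1ccc(OC(C)=O)c(OC)c1)/C=C/c1ccc(OC(C)=O)c(OC)c1` gives 0%

In a functional assay for inhibition, read by spectrophotometry, with a stated time of 30 min, tested at 1 uM (a lower number here means less inhibition, a higher number more inhibition at the concentration tested (going by the name of the read-out)), compound 1, compound 2 and compound 3 all sit at the floor of the read-out, and the three numbers lie within the usual scatter of one another. Compound 2 therefore stands level with compound 3 and with compound 1; the differences among them carry no meaning.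

Compound 4 `O=C(/C=C(/C=C/c1ccc(O)cc1)NC1CCCCC1)/C=C/c1ccc(O)cc1` differs from compound 2 by cyclohexyl in place of isobutyl on an amine nitrogen. Among the measured compounds shown here, nothing among the measured compounds ties a change at the amine nitrogen to any movement in this assay, and every measured value sits at the floor. The expectation is therefore that the step of a number 0.1 percentage points higher from compound 2 to compound 4 (within the scatter) stays within the scatter. For compound 4 the estimate in this assay is 0.1%, with a range from 0% to 8%.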

Compound 4, a percentage reported as inhibition, at one concentration (the size of the read-out at that concentration, not a potency): 0.03%
For compound 4 the middle estimate is 0.1 percentage points above the measured one; the measured number falls inside the stated range.
By their numbers in this assay, from the lowest: compounds 3, 2, 4 and 1 (each within the scatter of the next).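

In this assay, among the compounds shown here, cyclohexyl in place of isobutyl on an amine nitrogen gives a number 0 percentage points higher from compound 2 to compound 4 (within the scatter), the first step read at this position. Bringing in a six-membered non-aromatic ring of carbon only therefore leaves the number at the floor, and the step gives no sign that this nitrogen substituent governs the read-out. No supporting evidence bears on this result.

Since both compounds sit at the floor, the step cannot show what this change does above it. Going by these compounds, whether a carboxylic acid or a longer chain carrying an amine on this nitrogen would leave the floor remains open.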